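This account rests on a few compounds, and the source may have more. Where it says the series, first, only, none or still open, it means among the compounds named here.

In a functional assay on MCF7 cells (Homo sapiens) for cytotoxicity, read by sulforhodamine B assay, with a stated time of 48 h (a lower number here means a stronger inhibitor, a higher number a weaker inhibitor), compound 1 (`O=C(c1cccnc1)c1cc(F)ccc1O`) gives 27800 nM and compound 2 (`O=C(c1cccnc1)c1ccccc1O`) gives 24600 nM and these two values, the only ones so far, stand level within the scatter. The change from compound 2 to compound 3 (`O=C(c1cccnc1)c1cccc(Cl)c1O`) is chloro in place of hydrogen on an aromatic carbon and amounts to chloro in place of hydrogen on an aromatic carbon, ortho to a hydroxy group. Within the data shown here, the sole measured step (a 1.1-fold lower number from compound 1 to compound 2 (0.05 log units; within the scatter)) stayed within the scatter and involved fluoro, not chloro, so no shift beyond the scatter is expected in this assay for compound 3. Compound 3 is estimated at 20000 nM (expected range 9000 nM to 45000 nM). The estimated step also lies within the scatter (a 1.2-fold lower number from compound 2 to compound 3 (0.09 log units; within the scatter)).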

Compound 3, half-maximal inhibitory concentration: 26700 nM
For compound 3 the middle estimate is 1.3-fold (0.13 log units) below the measured one; the range from low to high includes it.
By their numbers in this assay, from the lowest: compounds 2, 3 and 1 (each within the scatter of the next).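

Chloro in place of hydrogen, ortho to a hydroxy group, gives no shift beyond the scatter in this assay (with a 1.1-fold higher number from compound 2 to compound 3 (0.04 log units; within the scatter)). This position therefore accepts a chlorine without a readable change, which the earlier fluoro step, at another place on the ring, could not show. No measurement at hand offers an explanation for this flat result.

On these data alone, whether an amine, a carboxylic acid or a longer chain at this position would move the number beyond the scatter remains open. So does the effect of replacing the hydroxy group itself with a methoxy group.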